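Swapping the halogenated phenyl ether in a diamino core

The source may report more compounds than this note shows. Statements on the series, on what has been measured and on what is new or still open speak of the compounds shown alone.

Compound 1 `NC1=NC2(CCOCC2)N(OCCCOc2cccc(Cl)c2Cl)C(N)=N1`: 330 nM
Compound 2 `NC1=NC2(CCSCC2)N(OCCCOc2ccccc2Br)C(N)=N1`: 90 nM

In a functional assay on HepG2 cells (Homo sapiens) for antiproliferative activity, read by MTT assay, with a stated time of 72 h (on this read-out lower numbers stand for stronger inhibition and higher numbers for weaker inhibition), compound 1 gives 330 nM, the highest number of the two measured; compound 2 gives 90 nM, and the gap between the two lies beyond the scatter. Compound 2 differs from compound 1 in more than one place, so its values alone say nothing about any single change.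

Compound 3 `NC1=NC2(CCOCC2)N(OCCCOc2cccc(Br)c2)C(N)=N1` differs from compound 1 only by 3-bromophenyl in place of 2,3-dichlorophenyl on an oxygen on a saturated carbon. Within the data shown here, with no single-change step measured, compound 3 is expected to stay close to compound 1, with a 1.2-fold higher number from compound 1 to compound 3 (0.08 log units; within the scatter) not beyond the scatter. Compound 3 is estimated at 400 nM, between 120 nM and 1300 nM.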

Compound 3, half-maximal inhibitory concentration: 320 nM
The estimate for compound 3 lay 1.3-fold (0.10 log units) above the measured number, within the range that was stated.
By their numbers in this assay, from the lowest: compound 2; then compounds 3 and 1 (each within the scatter of the next).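

Going to 3-bromophenyl in place of 2,3-dichlorophenyl on an oxygen on a saturated carbon leaves the read-out in this assay where it was, with a 1.0-fold lower number from compound 1 to compound 3 (0.01 log units; within the scatter). Among these compounds, this is the first comparison that isolates a single change, which compound 1 and compound 2 could not give, and at this place the two halogenated phenyl groups cannot be told apart. No measurement shown offers a reason for this. As far as these compounds go, whether a phenyl group carrying an amine or a carboxylic acid would give a similar number at this place remains open, as does the outcome with a longer chain on the oxygen.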